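The source may report more compounds than this note shows. Statements on the series, on what has been measured and on what is new or still open speak of the compounds shown alone.

Working notes on the series.

Compound 1 `COc1cc2c(cc1OC)C(=O)C(CC1CCN(C(=S)Nc3ccccc3)CC1)C2` and compound 2 `COc1cc2c(cc1OC)C(=O)C(CC1CCN(C(=S)Nc3ccc(Cl)cc3)CC1)C2` share one core and differ at the aromatic ring on the thiourea nitrogen. In a functional assay on the whole organism (strain Swiss albino) with Mus musculus as the target, in the maximal electroshock model, with a stated time of 4 h (a higher number here means that more compound is needed for the effect, a lower number that less compound is needed), compound 1 gives 300 mg/kg, and compound 2 gives 100 mg/kg. Among the compounds with values here, the only measured step is a 3.0-fold lower number from compound 1 to compound 2 (0.48 log units; beyond the scatter), so compound 2 stands at the lowest of the two numbers, with compound 1 the nearest neighbour.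

Compound 3 `CCCCNC(=S)N1CCC(CC2Cc3cc(OC)c(OC)cc3C2=O)CC1` is the next step from compound 2: butyl in place of 4-chlorophenyl on an amide-type nitrogen. Within the data shown here, no measured step bears directly on this change; the one step known, from compound 1 to compound 2, concerns chloro in place of hydrogen on an aromatic carbon, and the whole 4-chlorophenyl ring now leaves in favour of a butyl chain. Since the chloro on that ring went with the lower number of compound 2 in 100 mg/kg, removing the ring is expected to cost some of that gain, giving a modest rise in this assay rather than none.

Compound 3 is therefore estimated at 200 mg/kg in this assay, with a range of 100 mg/kg to 400 mg/kg, which is a step of a 2.0-fold higher number from compound 2 to compound 3 (0.30 log units; within the scatter) expected from compound 2.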

Compound 3, minimum effective dose: 100 mg/kg
Estimate against measurement, compound 3: 2.0-fold (0.30 log units) above, within the range that was stated.
By their numbers in this assay, from the lowest: compounds 2 and 3 (each within the scatter of the next); then compound 1.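

In this assay, the aromatic ring on the amide-type nitrogen turns out not to be needed to hold the number of compound 2: with butyl in place of 4-chlorophenyl, the step reads (no change at the digits printed from compound 2 to compound 3 (within the scatter)). Set against the unsubstituted ring, butyl in place of phenyl gives (a 3.0-fold lower number from compound 1 to compound 3 (0.48 log units; beyond the scatter)), so the chloro substituent is not the only change at this position that separates a compound from compound 1, and among these three compounds, compound 1 alone stands apart. Nothing measured here explains why two such different groups, 4-chlorophenyl and butyl, give matching numbers.

On these data alone, whether the number at this nitrogen follows chain length remains open, and a shorter propyl chain, a longer hexyl chain or a saturated cyclohexyl ring would test that. As far as these compounds go, it is also open whether any group here can take the minimum effective dose clearly under the level shared by compound 2 and compound 3, for instance a butyl chain ending in a hydroxyl group or an amine.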